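This account rests on a few compounds, and the source may have more. Where it says the series, first, only, none or still open, it means among the compounds named here.

Values in an ADME assay on MDBK cells (Bos taurus) for cytotoxicity, read by MTT assay, with a stated time of 96 h (a higher number here means that more compound is tolerated, a lower number that less compound is tolerated), for the series
compound 1 `FC(F)(F)c1cccc(NC(=S)Nc2ccc(I)cc2)c1` gives 9500 nM
compound 2 `FC(F)(F)c1cccc(NC(=S)Nc2ccc(Cl)cc2)c1` gives 17000 nM
compound 3 `COc1cccc(NC(=S)Nc2cccc(C(F)(F)F)c2)c1` gives 52000 nM

Compound 1 sits with compound 2 at the low end of these numbers, the two lying within the scatter of each other, while compound 3 gives a clearly higher number than compound 1. Still unmeasured is compound 4 `FC(F)(F)c1cccc(NC(=S)Nc2ccccc2)c1` with the change hydrogen in place of iodo on an aromatic carbon in the core of compound 1: hydrogen in place of iodo on an aromatic carbon, para to a large group, or 4-iodophenyl to phenyl. Within the data shown here, one measured step bears on it, namely a 1.8-fold higher number from compound 1 to compound 2 (0.25 log units; within the scatter) at that same carbon. On that step alone, a move to a somewhat higher number of similar size is expected in this assay and nothing clearly beyond the scatter. Among the measured compounds shown here, compound 3 is tied to compound 1 by no single change and shows only that numbers can run higher. For the measured compounds named here, no measured compound carries hydrogen at this place, so removal of the halogen itself is untested. The estimated step is a 1.9-fold higher number from compound 1 to compound 4 (0.28 log units; within the scatter) for this change. Compound 4 is expected at 18000 nM in an estimated range of 8500 nM to 42000 nM for this measurement.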

Compound 4, half-maximal cytotoxic concentration: 49000 nM
The estimate for compound 4 lay 2.7-fold (0.43 log units) below the measured number, and the stated range ends below it.
By their numbers in this assay, from the lowest: compounds 1 and 2 (each within the scatter of the next); then compounds 4 and 3 (each within the scatter of the next).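

In this assay, taking the halogen off this carbon gives a step beyond the scatter, both from iodo (a 5.2-fold higher number from compound 1 to compound 4 (0.71 log units; beyond the scatter)) and from chloro (a 2.9-fold higher number from compound 2 to compound 4 (0.46 log units; beyond the scatter)), whereas the exchange of one halogen for the other stayed within it (a 1.8-fold higher number from compound 1 to compound 2 (0.25 log units; within the scatter)). The position is therefore more sensitive to 4-iodophenyl to phenyl than the halogen exchange alone suggested, and among these four compounds the two halogen-bearing members, compound 1 and compound 2, hold the low end, with no compound going against that. Hydrogen and methoxy are not separated (a 1.1-fold lower number from compound 3 to compound 4 (0.03 log units; within the scatter)), and nothing at hand gives a reason for the difference between the halogenated and unhalogenated compounds.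

From the compounds shown here alone, whether the low numbers belong to halogens in general remains open, since bromo and fluoro at this carbon could each fall with compound 1 and compound 2 or stand with compound 4, and an amine or a carboxylic acid there is equally undecided. Also open, going by these compounds, is whether the same step holds when the trifluoromethyl group, constant across all four compounds, gives way to a nitrile.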